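Sulfonyl vinyl indoles: benzoyl to cyano swap

This account rests on a few compounds, and the source may have more. Where it says the series, first, only, none or still open, it means among the compounds named here.

Going by the values given here, compound 1 `O=C(/C(=C\c1c(-c2ccccc2)[nH]c2ccccc12)S(=O)(=O)c1ccccc1)c1ccccc1` stands at the high end of the two measured members in a functional assay on MCF7 cells (Homo sapiens) for inhibition, read by sulforhodamine B assay, with a stated time of 48 h (a lower number here means a stronger inhibitor of growth, a higher number a weaker inhibitor of growth), giving 5000 nM. Among the compounds with values here, compound 2 `COc1ccc2[nH]c(-c3ccccc3)c(C=C(C#N)C#N)c2c1` gives 2200 nM in this assay; no direct step between the two is computed, and the values show only that compound 2 carries the lower number. Compound 3 `N#C/C(=C\c1c(-c2ccccc2)[nH]c2ccccc12)S(=O)(=O)c1ccccc1` differs from compound 1 by cyano in place of benzoyl on a double-bonded chain carbon bound to a double-bonded chain carbon and a sulfonyl sulfur. A modest downward step is expected for compound 3, with the expected step being a 1.7-fold lower number from compound 1 to compound 3 (0.22 log units; within the scatter), possibly still within the scatter. Compound 3 is therefore estimated at 3000 nM, with a range of 1000 nM to 9000 nM.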

Compound 3, concentration for 50% growth inhibition: 2200 nM
Compound 3: the middle estimate sits 1.4-fold (0.13 log units) above what was measured, within the range that was stated.
By their numbers in this assay, from the lowest: compounds 2 and 3 (each within the scatter of the next); then compound 1.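

At the double-bonded chain carbon bound to a double-bonded chain carbon and a sulfonyl sulfur, the benzoyl group is not needed to retain growth inhibition in this assay: cyano in its place gives a 2.3-fold lower number from compound 1 to compound 3 (0.36 log units; beyond the scatter). The aromatic ring leaves with the benzoyl group and no ring enters, yet the number falls. No measurement here bears on the reason for this step.

Going by these compounds alone, the single swap does not separate loss of the ring from arrival of the nitrile. Going by these compounds, how a methyl ester, an amide or a carboxylic acid would behave at this place remains open.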